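Working notes: benzothiazolyl thioether benzamides against thiosulfate sulfurtransferase

The source may hold more compounds than are shown below. What is called first, only, known or untested is meant among the compounds shown, and "the series" means these compounds.

Compound 1 `O=C(Nc1ccc(Sc2nc3ccccc3s2)cc1)c1cc(Br)cc(Br)c1` in an assay on isolated protein for inhibition of thiosulfate sulfurtransferase (Homo sapiens), with a stated time of 60 min, in the absence of a further agent (a lower number here means a stronger inhibitor, a higher number a weaker inhibitor), gives > 100000 nM, a limit.
Compound 2 `COc1c(Br)cc(Br)cc1C(=O)Nc1ccc(Sc2nc3ccccc3s2)c(Cl)c1` in this assay gives > 100000 nM, a limit.
Compound 3 `O=C(Nc1ccc(Sc2nc3ccccc3s2)cc1)c1cc(Br)cc(Br)c1O` in this assay gives > 100000 nM, a limit.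

Compound 3 stands at the assay limit, and no number is known for it. Among the measured compounds shown here, the one measured step that reaches it, a step that the two limits leave unreadable from compound 1 to compound 3, runs between two limits and its size cannot be read. For the measured compounds named here, the only evidence on the whole set is the limit of > 100000 nM in this assay, at which 3 of the 3 values shown sit.

Compound 4 `COc1c(Br)cc(Br)cc1C(=O)Nc1ccc(Sc2nc3ccccc3s2)cc1` differs from compound 3 by methyl in place of hydrogen on an oxygen on an aromatic ring. Compound 2 also carries the methoxy group, with an added chlorine on the central ring, and its value is a limit as well. Going by the values given here, no measured step therefore tells anything about the size or direction of the methyl-for-hydrogen change in this assay; the expectation rests on all three compounds sitting at the limit.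

For compound 4 the expected step that the limit leaves unreadable from compound 3 to compound 4 is not readable beyond the scatter. Compound 4 is estimated to give 150000 nM, within 50000 nM to 500000 nM, most likely again reported only as a limit.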

Compound 4, half-maximal inhibitory concentration: > 100000 nM
Compound 4: a limit, no number; the forecaster's own chance of this, stated with the estimate: 90%; the middle value does not contradict the limit.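

Compound 4 joins compounds 1, 2 and 3 as a limit, so no step among these compounds can be read in this assay. What the compounds shown leave open is whether any change to the shared core gives a measurable value, the evidence being only this: the limit of > 100000 nM in this assay, at which 4 of the 4 values shown sit.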